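This account rests on a few compounds, and the source may have more. Where it says the series, first, only, none or still open, it means among the compounds named here.

Working notes on the series. Compound 1 `CN(Cc1cc(C(F)(F)F)cc(C(F)(F)F)c1)C(=O)c1cccnc1-c1ccccc1` is the open-chain member; in a functional assay on ileum for antagonist activity at Substance-P receptor (Cavia porcellus) (on this read-out higher numbers stand for weaker inhibition and lower numbers for stronger inhibition), compound 1 gives 151 nM. Compound 2 `O=C1c2c(-c3ccccc3)cc(N3CCCC3)nc2OCCCN1Cc1cc(C(F)(F)F)cc(C(F)(F)F)c1` carries the shared core of the cyclised members and gives 13.8 nM. Compound 3 `O=C1c2c(-c3ccccc3)cc(N3CCCCC3)nc2OCCCN1Cc1cc(C(F)(F)F)cc(C(F)(F)F)c1` gives 13.2 nM, the lowest of the three numbers, though its nearest neighbour compound 2 lies within the scatter, so no order between compounds 2 and 3 is claimed; only the gap to compound 1 is beyond the scatter. Among the compounds with values here, the one step that changes a single place, a 1.0-fold lower number from compound 2 to compound 3 (0.02 log units; within the scatter), is within the scatter.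

Compound 4 `CN1CCN(c2cc(-c3ccccc3)c3c(n2)OCCCN(Cc2cc(C(F)(F)F)cc(C(F)(F)F)c2)C3=O)CC1` is not yet measured. It differs from compound 3 in 4-methylpiperazin-1-yl in place of piperidin-1-yl on an aromatic carbon. Within the data shown here, the only step that bears on this place is the one from compound 2 to compound 3, where exchanging one saturated ring for another left the number unchanged within the scatter. On that basis no step beyond the scatter is expected for compound 4, with the estimated change being a 1.1-fold higher number from compound 3 to compound 4 (0.06 log units; within the scatter). For compound 4 the expected value is 15 nM, with an estimated range from 5 nM to 45 nM.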

Compound 4, antagonist equilibrium constant: 1.16 nM
Compound 4: middle estimate off by 13-fold (1.11 log units), on the high side, outside the stated range (below it).
By their numbers in this assay, from the lowest: compound 4; then compounds 3 and 2 (each within the scatter of the next); then compound 1.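

In this assay, within the data shown here, this position, on an aromatic carbon next to the ring nitrogen, proves sensitive to the choice of group: 4-methylpiperazin-1-yl gives an 11-fold lower number from compound 3 to compound 4 (1.06 log units; beyond the scatter) and a 12-fold lower number from compound 2 to compound 4 (1.08 log units; beyond the scatter) whereas the only earlier exchange here gave a 1.0-fold lower number from compound 2 to compound 3 (0.02 log units; within the scatter) and showed no such sensitivity. By count, 4-methylpiperazin-1-yl differs from piperidin-1-yl in having a six-membered non-aromatic ring with 2 hetero atoms rather than 1 and 2 hydrogen-bond acceptors rather than 1, with no net charge on either group. Nothing at hand accounts for the size of these steps.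

From the compounds shown here alone, whether the steps go with the second ring nitrogen or with its methyl stays open. Piperazin-1-yl with a free ring amine, morpholin-4-yl and an open-chain dimethylamino group at the same place would help separate these.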